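Shortening the thioether chain of compound 1

This account rests on a few compounds, and the source may have more. Where it says the series, first, only, none or still open, it means among the compounds named here.

In a functional assay on Fem-X cells (Homo sapiens) for cytotoxicity (a lower number here means a stronger inhibitor, a higher number a weaker inhibitor), compound 1 (`CCCCCCCCSC1=CC(=O)C(C[C@]2(C)[C@@H](C)CC[C@]3(C)C(C)=CCC[C@@H]23)=CC1=O`) reads > 100000 nM as a limit, not a number. For the measured compounds named here, compound 2 (`CC1CCC[C@H]2[C@](C)(CC3=CC(=O)C(Cl)=CC3=O)[C@@H](C)CC[C@]12C`) gives 32200 nM as the only actual number so far. Compound 3 (`CCCCSC1=CC(=O)C(C[C@]2(C)[C@@H](C)CC[C@]3(C)C(C)=CCC[C@@H]23)=CC1=O`) differs from compound 1 by hydrogen in place of butyl on a saturated chain carbon, four bonds along the chain from a sulfur in one place: hydrogen in place of butyl on a saturated chain carbon, four bonds along the chain from a sulfur. Going by the values given here, no measured step bears on this change. The estimated move an at least 2.0-fold lower number from compound 1 to compound 3 (0.30 log units; that floor lies within the scatter) is expected to be modest and towards stronger inhibition. That expectation leans on compound 2 at 32200 nM as the only numeric reference. For compound 3 the estimate is 50000 nM (expected range 15000 nM to 100000 nM) with a real chance of another limit.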

Compound 3, half-maximal inhibitory concentration: 24400 nM
Compound 3: middle estimate off by 2.0-fold (0.31 log units), on the high side, and the stated range covers the measured number.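

In this assay, for the compounds shown here, hydrogen in place of butyl on a saturated chain carbon, four bonds along the chain from a sulfur, gives an at least 4.0-fold lower number from compound 1 to compound 3 (0.61 log units; beyond the scatter), the first evidence that the length of this thioether chain bears on the read-out. Compound 1 stands at a limit, so this step is only a floor and its full size stays unknown: the limit of > 100000 nM in this assay, at which 1 of the 3 values shown sits.

As far as these compounds go, whether a shorter chain such as ethyl moves the number further remains open. So does the effect of a carboxylic acid or an amine at the end of the chain.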